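Swapping the pendant aryl ring in compound 1

The compounds below may be only part of what the source reports. "The series", "measured", "known", "first", "only" and "open" are said of these compounds alone.

Compound 1 `CCc1nn2c(-c3ccc(OC)cc3Cl)cccc2c1N(CC1CC1)CC1CC1` is a corticotropin-releasing factor receptor 1 antagonist. In a functional assay on HEK293 cells for antagonist activity at corticotropin-releasing factor receptor 1 (Homo sapiens), read by fluorescence and cAMP accumulation, with a stated time of 30 min (on this read-out higher numbers stand for weaker inhibition and lower numbers for stronger inhibition), compound 1 gives 100 nM. Among the three measured compounds its number is the second highest: compound 2 `COCc1cc(OC)c(-c2cccc3c(N(CC4CCOCC4)CC4CC4)c(C#N)nn23)c(OC)c1` gives 52 nM in this assay, a number within the scatter of that of compound 1, and compound 3 `CCCN(CCC)c1c(CC)nn2c(-c3ccc(OC)cc3Cl)cccc12` gives 200 nM in this assay, the step of a 2.0-fold higher number from compound 1 to compound 3 (0.30 log units; within the scatter) likewise staying within the scatter. Among the compounds with values here, the only measured step, from compound 1 to compound 3, concerns the amine on the shared core and not the pendant aryl ring.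

Compound 4 `CCc1nn2c(-c3c(C)cc(OC)cc3C)cccc2c1N(CC1CC1)CC1CC1` differs from compound 1 in that pendant ring: 4-methoxy-2,6-dimethylphenyl in place of 2-chloro-4-methoxyphenyl on an aromatic carbon. Within the data shown here, no measured pair changes this ring, so nothing among the measurements speaks directly to this step. Among the measured compounds shown here, the step from compound 1 to compound 3 shows only that a change elsewhere on the core stayed within the scatter. For the measured compounds named here, with no direct precedent, the expectation for compound 4 is a step of a 1.3-fold lower number from compound 1 to compound 4 (0.10 log units; within the scatter) in this assay, which lies within the scatter, so compound 4 is estimated at 80 nM in this assay, with a range from 20 nM to 320 nM that reflects the absence of a guiding measurement.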

Compound 4, half-maximal inhibitory concentration: 90 nM
Estimate against measurement, compound 4: 1.1-fold (0.05 log units) below, within the range that was stated.
By their numbers in this assay, from the lowest: compounds 2, 4, 1 and 3 (each within the scatter of the next, the first and the last beyond it).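

Within the data shown here, this is the first measured pair that changes the pendant ring at this place, on an aromatic carbon next to the ring nitrogen, whereas the earlier step concerned only the amine. In this assay, replacing 2-chloro-4-methoxyphenyl with 4-methoxy-2,6-dimethylphenyl gives a 1.1-fold lower number from compound 1 to compound 4 (0.05 log units; within the scatter), so for these two rings the read-out does not separate one from the other, even though the chlorine of the leaving ring is gone and the entering ring is one heavy atom larger. Nothing measured here accounts for this outcome, and the result alone cannot say what the ring contributes to inhibition.

Both rings compared here are substituted phenyl rings that keep the methoxy group, so the result says nothing about whether a plain phenyl ring, a pyridyl ring or a phenyl ring carrying a carboxylic acid would also stay within the scatter at this place. Compound 2 has a different pendant ring as well, but it also differs from compound 1 elsewhere, so its ring cannot be judged separately.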